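A few compounds are considered here, and "the series" means these few. Any claim that something is new, unique, unknown or untested is made for them only; others in the source may bear on it.

Compound 1 `O=[N+]([O-])c1ccc(COc2ccc(Nc3ncnc4cc5c(cc34)OCCOCCO5)cc2)cc1` carries a (4-nitrobenzyl)oxy group on the aniline. In a functional assay on DU-145 cells (Homo sapiens) for antiproliferative activity, read by MTT assay, with a stated time of 72 h (on this read-out higher numbers stand for weaker inhibition and lower numbers for stronger inhibition), compound 1 gives > 100000 nM, which is a limit of the assay and not a number. Compound 2 `c1ccc(COc2ccccc2Nc2ncnc3cc4c(cc23)OCCOCCOCCO4)cc1` is the other measured member of the series; in this assay compound 2 gives 13900 nM. Among the measured compounds shown here, no step between these two is recorded, so the pair shows only a limit next to a measured value. Compound 3 `c1ccc(COc2ccc(Nc3ncnc4cc5c(cc34)OCCOCCO5)cc2)cc1` differs from compound 1 by hydrogen in place of nitro on an aromatic carbon. For the measured compounds named here, with compound 1 sitting at the limit of > 100000 nM in this assay, at which 1 of the 2 values shown sits, no measured step is available for this change, and the expectation is for a move toward stronger inhibition, with a real chance that compound 3 also returns only a limit. Compound 3 is therefore estimated at 30000 nM, between 5000 nM and 200000 nM, which means an expected step of an at least 3.3-fold lower number from compound 1 to compound 3 (0.52 log units; beyond the scatter).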

Compound 3, half-maximal inhibitory concentration: > 100000 nM
Compound 3 was reported as a limit; the forecaster's own chance of this, stated with the estimate: 30%; middle value at least 3.3-fold (0.52 log units) away from the limit.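

No new step can be read for hydrogen in place of nitro, since compound 1 and compound 3 both return only a limit in this assay: the limit of > 100000 nM in this assay, at which 2 of the 3 values shown sit.

The compounds shown leave open whether this change on the aromatic carbon alters inhibition at all.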